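A few compounds are considered here, and "the series" means these few. Any claim that something is new, unique, unknown or untested is made for them only; others in the source may bear on it.

Compound 1 `O=C(N[C@H](CO)C(=O)O)[C@@H]1C[C@@H](O)CN1` and compound 2 `O=C(O)[C@H](CO)NC(=O)[C@@H]1C[C@@H](O)CN1` share every atom and bond and differ only in how one stereocentre is drawn. In an ADME assay on the whole organism (Mus musculus, strain C57BL/6) for pharmacokinetics, read by HPLC, with a stated time of 6 h, at a dose of 25 mg/kg by the oral route (on this read-out lower numbers stand for lower exposure and higher numbers for higher exposure at the dose given), compound 1 gives 640 nM, and in this assay compound 2 gives 520 nM. The step of a 1.2-fold lower number from compound 1 to compound 2 (0.09 log units; within the scatter) is small, which fits the fact that (the fact that compounds 1 and 2 differ only in the configuration as drawn). Compound 2 therefore stands beside compound 1 in this assay, the two numbers lying within the usual scatter of each other, so neither can be called higher or lower in any meaningful sense.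

Compound 3 `O=C(O)[C@H](CO)NC(=O)[C@H]1C[C@@H](O)CN1` has not yet been measured in this assay. Compared with compound 2 the change is this: the two compounds have the same atoms and bonds and differ only in configuration as drawn: 1 of 3 stereo elements differ; a stereocentre at a saturated ring carbon is drawn S in compound 2 and R in compound 3. Among the compounds with values here, the only measured step that bears on it is the one from compound 1 to compound 2, a configuration change at a chain carbon that stayed within the scatter. Within the data shown here, no step at a ring carbon has been measured, so the expectation rests on that single precedent. Compound 3 is expected to show a step of no change at the digits printed from compound 2 to compound 3 (within the scatter), nothing beyond the scatter. The estimate for compound 3 in this assay is 520 nM, with a range from 200 nM to 1400 nM.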

Compound 3, maximal plasma concentration: 22700 nM
For compound 3 the middle estimate is 44-fold (1.64 log units) below the measured one; measured number above the stated range.
By their numbers in this assay, from the lowest: compounds 2 and 1 (each within the scatter of the next); then compound 3.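

The ring carbon behaves quite differently from the chain carbon in this assay: redrawing it from S to R gives a 44-fold higher number from compound 2 to compound 3 (1.64 log units; beyond the scatter), whereas redrawing the chain carbon gave only a 1.2-fold lower number from compound 1 to compound 2 (0.09 log units; within the scatter). Since no atom or bond changes, this large step rests on the configuration at that one ring carbon, the first stereocentre in the series shown to matter for exposure at the dose given: the fact that compounds 2 and 3 differ only in the configuration as drawn. Compound 1 and compound 3 differ at both the chain carbon and the ring carbon, and a 35-fold higher number from compound 1 to compound 3 (1.55 log units; beyond the scatter) is also large, which fits the ring carbon carrying the effect, although this pair alone cannot separate the two changes.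

The compounds shown leave open whether the R ring carbon gives the same high number when the chain carbon is drawn R, and whether the third stereocentre matters at all, since it stays the same throughout. They also leave open whether the effect of the ring carbon would survive a methyl ester in place of the carboxylic acid or a fluorine in place of the ring hydroxyl.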